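The source may report more compounds than this note shows. Statements on the series, on what has been measured and on what is new or still open speak of the compounds shown alone.

Measured so far in a functional assay on PC-3 cells (Homo sapiens) for cytotoxicity, read by MTT assay; on this read-out higher numbers stand for weaker inhibition and lower numbers for stronger inhibition:
Compound 1 `COc1ccc(-c2nnc(-c3c[nH]c4ccccc34)o2)cc1OC` gives > 1000000 nM, a limit of the assay.
Compound 2 `COc1cc(-c2nnc(-c3c[nH]c4ccccc34)o2)ccc1OCc1ccccc1` gives > 1000000 nM, likewise a limit.

Compound 2 therefore stands at the assay limit, where the other value shown also sits (the limit of > 1000000 nM in this assay, at which 2 of the 2 values shown sit). Compound 3 `COc1cc(-c2nnc(-c3cn(C)c4ccccc34)o2)ccc1OCc1ccccc1` differs from compound 2 by methyl in place of hydrogen on an aromatic nitrogen. Among the compounds with values here, the one measured step, a step that the two limits leave unreadable from compound 1 to compound 2, runs between two limits and has no readable size, so no measured step bears on this change. Compound 3 is expected to remain near the limit, with an expected step of a number no higher from compound 2 to compound 3 (the limit leaves the size open) of no size beyond the scatter. Compound 3 is estimated at 1000000 nM, range 150000 nM to 5000000 nM.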

Compound 3, half-maximal inhibitory concentration: > 1000000 nM
Compound 3: no number, only a limit (the forecaster's own chance of this, stated with the estimate: 75%); the middle value sits exactly at the limit.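

Compound 2 and compound 3 both sit at a limit in this assay, so the step between them cannot be read. The compounds shown leave open what size any of these changes has: the limit of > 1000000 nM in this assay, at which 3 of the 3 values shown sit.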